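The compounds below may be only part of what the source reports. "The series", "measured", "known", "first", "only" and "open" are said of these compounds alone.

Two compounds with a shared core have numbers in an assay on CHO cells for antagonist activity at transient receptor potential cation channel subfamily V member 1 (Homo sapiens), read by FLIPR (a lower number here means a stronger inhibitor, a higher number a weaker inhibitor), so far. Compound 1 `CS(=O)(=O)Nc1ccc(C(C(=O)NCc2ccc(C(F)(F)F)nc2SC2CCCCC2)C2CCCC2)cc1F` carries a cyclopentyl on the saturated chain carbon bound to an aromatic carbon and a carbonyl carbon, and in this assay compound 1 gives 103 nM. Compound 2 `Cc1ccc(C(C(=O)NCc2ccc(C(F)(F)F)nc2SC2CCCCC2)c2ccc(NS(C)(=O)=O)c(F)c2)cc1` carries a 4-methylphenyl at that same carbon, and in this assay compound 2 gives 7.5 nM. For the measured compounds named here, the one measured step, a 14-fold lower number from compound 1 to compound 2 (1.14 log units; beyond the scatter), is a large one, and it leaves compound 2 with the lowest number of the two.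

Compound 3 `Cc1ccc(CC(C(=O)NCc2ccc(C(F)(F)F)nc2SC2CCCCC2)c2ccc(NS(C)(=O)=O)c(F)c2)cc1` is not yet measured. It differs from compound 2 in one place: 4-methylbenzyl in place of 4-methylphenyl on a saturated chain carbon bound to an aromatic carbon and a carbonyl carbon. Going by the values given here, no measured step matches this change, so the step from compound 1 to compound 2 only shows that the group at this carbon matters strongly to this assay, without saying what a 4-methylbenzyl does there. Compound 3 is therefore expected to move back toward a higher number than compound 2, by a modest step of a 3.3-fold higher number from compound 2 to compound 3 (0.52 log units; beyond the scatter). The estimate for compound 3 in this assay is 25 nM, with a range from 6 nM to 110 nM.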

Compound 3, inhibition constant: 40.3 nM
Beside the measured number, compound 3's estimate is 1.6-fold (0.21 log units) below it, within the range that was stated.
By their numbers in this assay, from the lowest: compound 2; then compound 3; then compound 1.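

Lengthening the group at this carbon by one carbon, with 4-methylbenzyl in place of 4-methylphenyl, gives a 5.4-fold higher number from compound 2 to compound 3 (0.73 log units; beyond the scatter) in this assay and so gives back part of the gain seen with the aromatic group. The 4-methylbenzyl group still does better than cyclopentyl, with a 2.6-fold lower number from compound 1 to compound 3 (0.41 log units; beyond the scatter) at the same saturated chain carbon bound to an aromatic carbon and a carbonyl carbon, which places it between the other two groups in this set. Since 4-methylphenyl and 4-methylbenzyl have the same kind of aromatic ring and differ by a single heavy atom, the result shows that having this ring is not all that counts here, although no measured evidence says why the extra carbon changes the number.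

The compounds shown leave open whether the number keeps rising with a longer chain, such as 2-(4-methylphenyl)ethyl, at this carbon. They also leave open what the methyl on the ring contributes, which a plain phenyl or a phenyl bearing an amine or a carboxylic acid in its place could help to answer.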